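A Methyl on the Ring Carbon of Compound 2

This account rests on a few compounds, and the source may have more. Where it says the series, first, only, none or still open, it means among the compounds named here.

Of the compounds shown here, three sharing one core have been measured in a functional assay for agonist activity at follicle-stimulating hormone receptor (Homo sapiens), read by a luciferase reporter; on this read-out higher numbers stand for an effect only at larger amounts of compound and lower numbers for an effect already at smaller amounts. Compound 1 `CCCCCCCCCN1CC(=O)N(C)[C@@H](Cc2ccc(-c3cc(OC)c(OC)c(OC)c3)cc2)C1=O` gives 900 nM in this assay. Compound 2 `CCCCCCCCN1CC(=O)N(C)[C@@H](Cc2ccc(-c3cc(OC)c(OC)c(OC)c3)cc2)C1=O` gives 400 nM. Compound 3 `CCCCCCCCN1CC(=O)N(C)[C@@H](Cc2ccc(-c3cc(OC)cc(OC)c3)cc2)C1=O` gives 5000 nM. Among these three numbers compound 2 stands lowest: the step of a 2.3-fold lower number from compound 1 to compound 2 (0.35 log units; beyond the scatter) separates it from compound 1, and the step of a 13-fold higher number from compound 2 to compound 3 (1.10 log units; beyond the scatter) separates it from compound 3, both beyond the scatter.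

The unmeasured compound 4 `CCCCCCCCN1C(=O)[C@H](Cc2ccc(-c3cc(OC)c(OC)c(OC)c3)cc2)N(C)C(=O)[C@H]1C` differs from compound 2 by methyl in place of hydrogen on a saturated ring carbon, placed on a saturated ring carbon of the six-membered non-aromatic ring with 2 nitrogen, next to the ring nitrogen and next to the ring atom that bears an octyl group.

Neither measured step touches such a ring carbon. The step from compound 1 to compound 2 concerns a saturated chain carbon eight bonds along the chain from an amide-type nitrogen, and the step from compound 2 to compound 3 concerns a methoxy on an aromatic carbon. Among the compounds with values here, no step for a substituent on this ring is available, so no direction can be read off, and the expectation is of a change in this assay of no more than modest size, or none beyond the scatter. Compound 4 is therefore estimated at 600 nM, with a range from 150 nM to 2500 nM. The step this estimate implies, a 1.5-fold higher number from compound 2 to compound 4 (0.18 log units; within the scatter), is expected to lie close to the scatter.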

Compound 4, half-maximal effective concentration: 120 nM
Compound 4: the middle estimate sits 5.0-fold (0.70 log units) above what was measured; the measured number lies below the stated range.
By their numbers in this assay, from the lowest: compound 4; then compound 2; then compound 1; then compound 3.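

In this assay the methyl on this saturated ring carbon brings a 3.3-fold lower number from compound 2 to compound 4 (0.52 log units; beyond the scatter), so this position on the ring of the shared core accepts a substituent and the number falls rather than rises. Within the data shown here, the earlier steps concerned only the far end of the chain on the ring nitrogen and a methoxy on an aromatic carbon, so this is the first sign that the ring itself can shift the result, here through a group of 1 heavy atom, and compound 4 now holds the lowest number of the four. No measurement at hand accounts for why this methyl lowers the number.

What the compounds shown leave open is how far this trend reaches on the same ring carbon: an ethyl, a hydroxymethyl or an aminomethyl in place of the methyl could continue it, stop it or reverse it. They also leave open what the methyl does when it points the opposite way on that carbon, and whether it lowers the number in the same way with a nonyl chain in place of the octyl group or with a hydrogen in place of one methoxy on the aromatic ring.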